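The source may report more compounds than this note shows. Statements on the series, on what has been measured and on what is new or still open speak of the compounds shown alone.

Measured compounds:
compound 1, `CC(Oc1ccccc1-c1ccc([N+](=O)[O-])cc1)C1=NCCN1` — < 0.3
compound 2, `CC(Oc1ccccc1-c1cccnc1)C1=NCCN1` — 1
compound 3, `CC(Oc1ccccc1-c1ccncc1)C1=NCCN1` — < 0.3

In a functional assay on CHO cells for agonist activity at Alpha-2C adrenergic receptor (Homo sapiens) (a higher number here means a larger maximal response, a lower number a smaller maximal response), compound 3 gives < 0.3, which is a limit of the assay and not a number. For the measured compounds named here, the one step among the measured compounds is a number at least 0.70 lower from compound 2 to compound 3 (beyond the scatter), a large fall that ends at this limit. The same limit holds for compound 1, whose value in this assay is < 0.3, so that the limit of < 0.3 in this assay, at which 2 of the 3 values shown sit, describes where two of the three measured compounds sit. Compound 2 alone reaches a full response in this assay.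

Compound 4, `CC(Oc1ccccc1-c1ccccc1O)C1=NCCN1`, has not yet been measured in this assay. It differs from compound 3 by 2-hydroxyphenyl in place of pyridin-4-yl on an aromatic carbon. No measured step carries this change, since the only step shown exchanges one pyridinyl for another; the measured compounds show only that the pyridin-3-yl of compound 2 gives a full response while the pyridin-4-yl of compound 3 and the 4-nitrophenyl of compound 1 stay at the limit. Going by the values given here, with no step on a hydroxyphenyl group, the expectation for compound 4 is wide and leans toward a partial response, so that the step a number at least 0.20 higher from compound 3 to compound 4 (beyond the scatter) is expected to be a rise from the limit of compound 3. Compound 4 is therefore estimated to give 0.5 in this assay, between 0.2 and 1.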

Compound 4, intrinsic activity: the largest response reached, as a fraction of the reference agonist's: < 0.3
Compound 4 ended at the assay's limit; the forecaster's own chance of this, stated with the estimate: 35%; middle value at least 0.20 away from the limit.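

The 2-hydroxyphenyl group, which unlike pyridin-4-yl carries a hydrogen-bond donor, does not bring back the full response at this position: in this assay the change gives a number at least 0.70 lower from compound 2 to compound 4 (beyond the scatter), a large fall like the one seen with the pyridin-4-yl of compound 3. The step between compound 3 and compound 4 cannot be read, as both of its ends are limits of the assay and not numbers. Compound 2, with its pyridin-3-yl, now stands alone at a full response, while three different aromatic groups, in compound 1, compound 3 and compound 4, all end at the same limit: the limit of < 0.3 in this assay, at which 3 of the 4 values shown sit.

The compounds shown leave open how far compound 1, compound 3 and compound 4 differ from one another under that limit, and why only the pyridin-3-yl group gives a full response, since no measured property bears on it. They also leave open whether a pyrimidinyl group, or a phenyl ring carrying an amine or a carboxylic acid, would give a full response, a partial response or none in this assay.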